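Swapping Trifluoromethyl for Bromo on the Aryl Ring

The source may report more compounds than this note shows. Statements on the series, on what has been measured and on what is new or still open speak of the compounds shown alone.

Compound 1, `COC(=O)C1=C(C)N=C(C)/C(=C(\O)OC)C1c1cccc(Cl)c1Cl`: 19.1 nM
Compound 2, `COC(=O)C1=C(C)N=C(C)/C(=C(\O)OC)C1c1cccc(C#N)c1`: 34.7 nM
Compound 3, `COC(=O)C1=C(C)N=C(C)/C(=C(\O)OC)C1c1ccccc1C(F)(F)F`: 1.51 nM

All three were tested in a functional assay (muscle tissue) with Cavia porcellus as the target; a higher number here means that more compound is needed for the effect, a lower number that less compound is needed. Compound 3 gives the lowest number of the three; compound 1 stands well above it and compound 2 higher still, both gaps beyond the scatter. Within the data shown here, the only single step among them, a 1.8-fold higher number from compound 1 to compound 2 (0.26 log units; within the scatter), exchanges the group on the saturated ring carbon and lies within the scatter. Compound 4, `COC(=O)C1=C(C)N=C(C)/C(=C(\O)OC)C1c1ccccc1Br`, differs from compound 3 as follows: bromo in place of trifluoromethyl on an aromatic carbon; the change sits ortho to a large group. Among the measured compounds shown here, no measured step exchanges a group on an aromatic carbon, so the one known step bears only loosely on this change. A modest rise in this assay is expected: a 3.0-fold higher number from compound 3 to compound 4 (0.47 log units; beyond the scatter). Compound 4 is therefore estimated at 4.5 nM, with a range from 1.2 nM to 17 nM.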

Compound 4, half-maximal effective concentration: 7.59 nM
Beside the measured number, compound 4's estimate is 1.7-fold (0.23 log units) below it; low and high end bracket the measured number.
By their numbers in this assay, from the lowest: compound 3; then compound 4; then compounds 1 and 2 (each within the scatter of the next).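

In this assay, among these compounds, trifluoromethyl to bromo is the first measured exchange on an aromatic carbon, and bromo does not keep the lowest number (a 5.0-fold higher number from compound 3 to compound 4 (0.70 log units; beyond the scatter)). The 2-bromophenyl group still gives a lower number than either 3-cyanophenyl (a 4.6-fold lower number from compound 2 to compound 4 (0.66 log units; beyond the scatter)) or 2,3-dichlorophenyl (a 2.5-fold lower number from compound 1 to compound 4 (0.40 log units; beyond the scatter)). So this place tolerates bromo, though less well than trifluoromethyl.

From the compounds shown here alone, whether an amine or a methoxy group here would reach the number of trifluoromethyl remains open. Nothing available explains these differences.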